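The source may hold more compounds than are shown below. What is called first, only, known or untested is meant among the compounds shown, and "the series" means these compounds.

Working notes on the series. Compound 1 `c1cc2ccc(CN3CCCCC3)ccc-2c1` reaches only a limit of the assay in a physicochemical assay for lipophilicity (on this read-out lower numbers stand for lower lipophilicity and higher numbers for higher lipophilicity), recorded as > 5.5, which is the limit of > 5.5 in this assay, at which 1 of the 3 values shown sits, and not a number. Compound 2 `O=C(NCCO)c1ccc2ccc(C(=O)c3ccccc3)c-2cc1` gives 2.2 in this assay. Compound 3 `O=C(Nc1cc2cccccc-2c1)c1cccnc1` gives 2.4 in this assay; compound 2 and compound 3 lie within the scatter of each other, so no order between them is claimed. Compound 4 `O=C(NCc1cccnc1)c1ccc2ccc(C(=O)c3ccccc3)c-2cc1` is not yet measured and differs from compound 2 by pyridin-3-yl in place of hydroxymethyl on a saturated chain carbon bound to an amide-type nitrogen. For the measured compounds named here, no measured step of this kind exists among the three measured compounds. With hydroxymethyl leaving and pyridin-3-yl entering, the step of a number 1.00 log units higher from compound 2 to compound 4 (beyond the scatter) in this assay is expected to be an increase beyond the scatter. Compound 4 is estimated in this assay at 3.2, with a range from 2.6 to 3.8.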

Compound 4, partition coefficient: 3
The estimate for compound 4 lay 0.20 log units above the measured number; low and high end bracket the measured number.
By their numbers in this assay, from the lowest: compounds 2 and 3 (each within the scatter of the next); then compound 4. At a limit, above all of these: compound 1.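

For the compounds shown here, on a saturated chain carbon bound to an amide-type nitrogen, pyridin-3-yl in place of hydroxymethyl reads in this assay as a number 0.80 log units higher from compound 2 to compound 4 (beyond the scatter) and gives the first step between measured compounds that differ in one place. This reading of the change rests on that single pair. No measurement shown bears on a cause for the step.

As far as these compounds go, whether an amine or a carboxylic acid in place of pyridin-3-yl, or a longer chain carrying pyridin-3-yl, would give a step of similar size stays open. From the compounds shown here alone, whether the same change gives a similar step on another core also stays open.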